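The source may hold more compounds than are shown below. What is called first, only, known or untested is meant among the compounds shown, and "the series" means these compounds.

Of the compounds shown here, two built on a shared core have been measured in a functional assay on NIH3T3 cells (Mus musculus); on this read-out lower numbers stand for an effect already at smaller amounts and higher numbers for an effect only at larger amounts of compound. Compound 1, `CSCC[C@H](NC(=O)c1ccc(NCc2cncn2Cc2cccc(C)c2)cc1-c1ccccc1)C(=O)O`, returns only a limit of the assay, > 10 uM. Compound 2, `CC(C)NC(=O)c1ccc(NCc2cncn2Cc2ccc(C#N)cc2)cc1-c1ccccc1`, likewise returns only a limit, > 10 uM. Both results sit at the same place, (the limit of > 10 uM in this assay, at which 2 of the 2 values shown sit), so the two compounds cannot be ordered against each other and no step can be read between them. The compound not yet measured is compound 3, `CSCC[C@H](NC(=O)c1ccc(NCc2cncn2Cc2ccc(C#N)cc2)cc1-c1ccccc1)C(=O)O`. It is reached from compound 2 by a single change on the amide-type nitrogen whose other neighbour is the carbonyl carbon: 1-carboxy-3-(methylsulfanyl)propyl in place of isopropyl on an amide-type nitrogen. Going by the values given here, no measured step covers this change, so its size is open; still, compound 1 already carries the same 1-carboxy-3-(methylsulfanyl)propyl group on its amide nitrogen and stays at the limit. Compound 3 is therefore expected to show a step that the limit leaves unreadable from compound 2 to compound 3, none beyond the scatter in this assay. For compound 3 the expected value in this assay is 15 uM, with a range from 5 uM to 50 uM, and most probably once more only a limit.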

Compound 3, concentration for half-maximal effect: > 10 uM
Compound 3 gave a limit, no number; the forecaster's own chance of this, stated with the estimate: 75%; the middle value does not contradict the limit.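

Compound 3 returns only a limit of the assay, just as compound 1 and compound 2 do, so neither its step from compound 2 nor its step from compound 1 can be read: the limit of > 10 uM in this assay, at which 3 of the 3 values shown sit.

The compounds shown leave open how far past that limit each one lies, and whether swapping isopropyl for 1-carboxy-3-(methylsulfanyl)propyl or 3-methylphenyl for 4-cyanophenyl changes the effect at all.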